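Sulfonyl substituent truncation in the EP3 series

The source may report more compounds than this note shows. Statements on the series, on what has been measured and on what is new or still open speak of the compounds shown alone.

Going by the values given here, compound 1 `Cc1cn(Cc2ccc(Cl)cc2Cl)c2c(-c3nnc(NS(=O)(=O)c4cc(Cl)c(Cl)s4)o3)cc(F)cc12` gives 10 nM in an assay on isolated protein for displacement of a labelled ligand from prostaglandin E2 receptor EP3 subtype (Homo sapiens) (a lower number here means a stronger inhibitor, a higher number a weaker inhibitor), the highest of the two numbers measured so far; compound 2 `Cc1cn(Cc2ccc(Cl)cc2Cl)c2c(-c3nnc(NS(=O)(=O)c4cc(F)c(F)cc4F)o3)cc(F)cc12` gives 2 nM, and the step of a 5.0-fold lower number from compound 1 to compound 2 (0.70 log units; beyond the scatter) swaps one aromatic ring for another at the sulfonyl sulfur. Compound 3 `Cc1cn(Cc2ccc(Cl)cc2Cl)c2c(-c3nnc(NS(C)(=O)=O)o3)cc(F)cc12` carries methyl in place of 4,5-dichlorothiophen-2-yl on a sulfonyl sulfur. Among the compounds with values here, only the step from compound 1 to compound 2 bears on this position, and it leaves the ring in place, so no measured step covers removal of the ring; the expectation for compound 3 is a weaker inhibitor, with a step of a 25-fold higher number from compound 1 to compound 3 (1.40 log units; beyond the scatter). Compound 3 is estimated at 250 nM, range 30 nM to 2000 nM.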

Compound 3, half-maximal inhibitory concentration: 2570 nM
The estimate for compound 3 lay 10-fold (1.01 log units) below the measured number; the measured number lies above the stated range.
By their numbers in this assay, from the lowest: compound 2; then compound 1; then compound 3.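

Putting methyl on the sulfonyl sulfur costs far more in this assay than exchanging one aromatic ring for the other: the large steps (a 260-fold higher number from compound 1 to compound 3 (2.41 log units; beyond the scatter)) and (a 1300-fold higher number from compound 2 to compound 3 (3.11 log units; beyond the scatter)) compare with a modest change between the two ring compounds. Among these three compounds, the aromatic rings at this position go with the lower numbers, and methyl goes with the highest. Nothing available explains the size of this loss.

Still open, as far as these compounds go, is whether an aromatic ring is required here or any larger group would serve. A longer alkyl chain, a cyclohexyl ring or a benzyl group on the sulfonyl sulfur would separate these possibilities.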